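A few compounds are considered here, and "the series" means these few. Any claim that something is new, unique, unknown or untested is made for them only; others in the source may bear on it.

Values in an ADME assay on NHDF cells (Homo sapiens) for cytotoxicity, read by MTT assay, with a stated time of 72 h; on this read-out higher numbers stand for weaker inhibition and lower numbers for stronger inhibition:

- Compound 1 `COc1cccc(/C=C2\CCC/C(=C\c3ccccc3Br)C2=O)c1OC`: > 50000 nM (a limit)
- Compound 2 `COc1cccc(/C=C2\CCC/C(=C\c3cccc(O)c3)C2=O)c1OC`: 19300 nM
- Compound 3 `COc1cccc(/C=C2\CCC/C(=C\c3ccc(O)cc3)C2=O)c1OC`: > 50000 nM (a limit)

Compound 3 gives only a limit, and it shares this with compound 1: the limit of > 50000 nM in this assay, at which 2 of the 3 values shown sit. Compound 4 `COc1cccc(/C=C2\CCC/C(=C\c3ccc(O)c(Cl)c3)C2=O)c1OC` carries one change from compound 3: chloro in place of hydrogen on an aromatic carbon. This is chloro in place of hydrogen on an aromatic carbon, ortho to a hydroxy group.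

Among the measured compounds shown here, no measured step makes this exact change. The nearest steps alter the same aromatic ring: an at least 2.5-fold lower number from compound 1 to compound 2 (0.41 log units; beyond the scatter) and an at least 2.5-fold higher number from compound 2 to compound 3 (0.41 log units; beyond the scatter). The step that the two limits leave unreadable from compound 1 to compound 3 adds no size. A modest move to a lower number in this assay is therefore expected, though another limit remains possible. The expected step is an at least 1.6-fold lower number from compound 3 to compound 4 (0.22 log units; that floor lies within the scatter). Compound 4 is estimated at 30000 nM, with an expected range of 12000 nM to 60000 nM.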

Compound 4, half-maximal inhibitory concentration: 39500 nM
The estimate for compound 4 lay 1.3-fold (0.12 log units) below the measured number; low and high end bracket the measured number.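

Going from 4-hydroxyphenyl to 3-chloro-4-hydroxyphenyl turns a limit into a measured number in this assay: an at least 1.2-fold lower number from compound 3 to compound 4 (0.10 log units; that floor lies within the scatter). Against 3-hydroxyphenyl the same group gives a 2.0-fold higher number from compound 2 to compound 4 (0.31 log units; beyond the scatter), so a hydroxy group plus chloro on this aromatic ring does not match the lowest number in the set. Against 2-bromophenyl the reading is an at least 1.2-fold lower number from compound 1 to compound 4 (0.10 log units; that floor lies within the scatter), and the series keeps its ceiling: the limit of > 50000 nM in this assay, at which 2 of the 4 values shown sit.

As far as these compounds go, the true size of the chloro step stays open, since only its floor can be read. Also open, from the compounds shown here alone, is what fluoro or an amine in the same place would give in this assay.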